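Metabolic stability notes: tetrazole to hydroxymethyl thiane dioxide

The compounds below may be only part of what the source reports. "The series", "measured", "known", "first", "only" and "open" are said of these compounds alone.

Measured so far in an ADME assay on microsomes from liver (Mus musculus) for metabolic stability, with a stated time of 10 min; a higher number here means that more of the compound is left, a lower number that less of the compound is left:
compound 1 `COC[C@]1(C(=O)N2CC[C@](c3ccc(C(F)(C(F)(F)F)C(F)(F)F)cc3)(S(=O)(=O)c3ccc(F)cc3)C2)CC[C@H](C(=O)O)CC1` gives 88%
compound 2 `O=C([C@H]1CC[C@H](c2nnn[nH]2)CC1)N1CC[C@](c2ccc(C(F)(C(F)(F)F)C(F)(F)F)cc2)(S(=O)(=O)c2ccc(F)cc2)C1` gives 73%
compound 3 `O=C(C1CCS(=O)(=O)C1)N1CC[C@](c2ccc(C(F)(C(F)(F)F)C(F)(F)F)cc2)(S(=O)(=O)c2ccc(F)cc2)C1` gives 78%; 96% (2 entries)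

Compound 2 holds the lowest of the two single numbers in this assay. Among the measured compounds shown here, its only single-number neighbour is compound 1, and the two are separated by a number 15 percentage points lower from compound 1 to compound 2 (beyond the scatter), a step beyond the scatter, in which 4-(1H-tetrazol-5-yl)cyclohexyl took the place of 4-carboxy-1-(methoxymethyl)cyclohexyl on a carbonyl carbon. Compound 3 contributes no single number; its repeats, (the several entries of compound 3 in this assay, 78%; 96% (2 entries)), show how far two readings of one compound can lie apart in this assay.

Compound 4 `O=C(N1CC[C@](c2ccc(C(F)(C(F)(F)F)C(F)(F)F)cc2)(S(=O)(=O)c2ccc(F)cc2)C1)C1(CO)CCS(=O)(=O)CC1` is not yet measured. It differs from compound 2 as follows: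
4-(hydroxymethyl)-1,1-dioxothian-4-yl in place of 4-(1H-tetrazol-5-yl)cyclohexyl on a carbonyl carbon

For the measured compounds named here, the one measured step that bears on this change is the one into compound 2, which brought the tetrazole in and lost ground. Compound 4 leaves the tetrazole again, and its entering group carries the same sulfone-bearing ring as the acyl group of compound 3. The expected step is therefore upward, of about the size lost before, a number 12 percentage points higher from compound 2 to compound 4 (beyond the scatter), though it may prove to sit within the scatter. Compound 4 is estimated at 85%, with a range from 70% to 97%.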

Compound 4, percent of the compound remaining: 31%
Beside the measured number, compound 4's estimate is 54 percentage points above it; the whole stated range lies above it.
By their numbers in this assay, from the lowest: compound 4; then compound 2; then compound 1.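

In this assay, among the compounds shown here, the place on the carbonyl carbon proves able to carry a much larger swing than the earlier compounds showed: 4-(hydroxymethyl)-1,1-dioxothian-4-yl in place of 4-(1H-tetrazol-5-yl)cyclohexyl gives a number 42 percentage points lower from compound 2 to compound 4 (beyond the scatter), and in place of 4-carboxy-1-(methoxymethyl)cyclohexyl it gives a number 57 percentage points lower from compound 1 to compound 4 (beyond the scatter). Compound 4 therefore has the lowest of the three single numbers, and the shared core alone does not secure a high number in this series. Both steps are also wider than the distance between repeat readings of a single compound: the several entries of compound 3 in this assay, 78%; 96% (2 entries).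

The hydroxymethyl group and the 1,1-dioxothian ring enter together and no compound shown separates them, so it remains open which part of the new group goes with the drop. A methyl group or an amine in place of the hydroxymethyl on the same ring would be a one-place comparison with compound 4 and would begin to answer this.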